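A longer phenoxy-terminated chain on a crown ether ester

A few compounds are considered here, and "the series" means these few. Any claim that something is new, unique, unknown or untested is made for them only; others in the source may bear on it.

Measured so far:
compound 1 `O=C(CCCCCc1ccccc1)OCC1COCCOCCOCCOCCOCCO1` gives 79000 nM
compound 2 `O=C(CCCCC1CCCCC1)OCC1COCCOCCOCCOCCOCCO1` gives 71000 nM

In a functional assay on HeLa cells (Homo sapiens) for inhibition, read by sulforhodamine B assay, with a stated time of 48 h (on this read-out higher numbers stand for weaker inhibition of growth and lower numbers for stronger inhibition of growth), compound 1 and compound 2 cannot be told apart, since a 1.1-fold lower number from compound 1 to compound 2 (0.05 log units; within the scatter) lies within the scatter. Compound 3 `O=C(CCCCCCCCCCOc1ccccc1)OCC1COCCOCCOCCOCCOCCO1` differs from compound 1 by 5-phenoxypentyl in place of phenyl on a saturated chain carbon, five bonds along the chain from a carbonyl carbon. For the measured compounds named here, no measured step lengthens the chain or adds an ether oxygen; the one known step swaps only the end ring and shows no movement. Compound 3 is therefore expected to show a 1.3-fold lower number from compound 1 to compound 3 (0.12 log units; within the scatter), nothing beyond the scatter. The estimate for compound 3 is 60000 nM, with a range from 20000 nM to 200000 nM.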

Compound 3, concentration for 50% growth inhibition: 41000 nM
For compound 3 the middle estimate is 1.5-fold (0.17 log units) above the measured one; measured number inside the range.
By their numbers in this assay, from the lowest: compounds 3, 2 and 1 (each within the scatter of the next).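

In this assay, the change at this place, on a saturated chain carbon, five bonds along the chain from a carbonyl carbon, gives a 1.9-fold lower number from compound 1 to compound 3 (0.28 log units; within the scatter) for 5-phenoxypentyl in place of phenyl. The earlier pair swapped only the end ring, whereas this step takes the group from 6 to 12 heavy atoms and adds an oxygen, and the number still stays within the scatter. Nothing measured here bears on this result.

Still open, on these data alone, is whether an amine or a carboxylic acid at the end of this chain would move the number beyond the scatter.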